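The compounds below may be only part of what the source reports. "The series", "measured", "known", "first", "only" and "open" are said of these compounds alone.

compound 1 `COc1ccc(SCc2ccc(C(=O)Nc3ccccc3N)cc2)cc1`: 2170 nM
compound 2 `CCc1ccc(SCc2ccc(C(=O)Nc3ccccc3N)cc2)cc1`: 1750 nM
compound 3 `Nc1ccccc1NC(=O)c1ccc(CSc2cccc(F)c2)cc1`: 3280 nM

All three values come from a functional assay on SMMC-7721 cells (Homo sapiens) for antiproliferative activity, read by CCK-8 assay, with a stated time of 72 h; on this read-out lower numbers stand for stronger inhibition and higher numbers for weaker inhibition. Compound 3 is not separated from either of the other two: the measured steps are a 1.5-fold higher number from compound 1 to compound 3 (0.18 log units; within the scatter) and a 1.9-fold higher number from compound 2 to compound 3 (0.27 log units; within the scatter). For now, the three compounds count as one level.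

The next change gives compound 4 `Cc1ccc(SCc2ccc(C(=O)Nc3ccccc3N)cc2)cc1`: 4-methylphenyl in place of 3-fluorophenyl on a sulfur. In words, this is 4-methylphenyl in place of 3-fluorophenyl on a sulfur. Among the compounds with values here, no measured step makes exactly this exchange. The nearest evidence is the two steps above, read in reverse, since they exchange 3-fluorophenyl with 4-methoxyphenyl and 4-ethylphenyl on the same sulfur. The step of a 1.2-fold lower number from compound 1 to compound 2 (0.09 log units; within the scatter) also matters, as it shows that exchanging those two groups leaves the number within the scatter. Compound 4 is therefore expected to sit with compound 1 and compound 2, with no shift beyond the scatter in this assay, and any drift is expected towards a lower number. The expected step is a 1.7-fold lower number from compound 3 to compound 4 (0.23 log units; within the scatter). For compound 4 the estimated value is 1950 nM, with an expected range of 1100 nM to 3500 nM.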

Compound 4, half-maximal inhibitory concentration: 3740 nM
Compound 4: the middle estimate sits 1.9-fold (0.28 log units) below what was measured; the measured number lies above the stated range.
By their numbers in this assay, from the lowest: compounds 2, 1, 3 and 4 (each within the scatter of the next, the first and the last beyond it).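

In this assay, the exchange of 3-fluorophenyl for 4-methylphenyl on the sulfur gives a 1.1-fold higher number from compound 3 to compound 4 (0.06 log units; within the scatter), and the exchange of methoxy for methyl on the aromatic carbon gives a 1.7-fold higher number from compound 1 to compound 4 (0.24 log units; within the scatter), so neither exchange separates compound 4 from its partner. Within the data shown here, the one exchange that does is the loss of a single carbon from the ethyl group, with hydrogen in place of methyl on the saturated chain carbon bound to an aromatic carbon: this gives a 2.1-fold higher number from compound 2 to compound 4 (0.33 log units; beyond the scatter), a modest step and the first pair at this position to lie beyond the scatter, although compound 1 and compound 3 remain within the scatter of both ends and no ordered trend can be drawn. Nothing measured on these compounds bears on this step.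

From the compounds shown here alone, whether the gap between the ethyl and methyl compounds continues with a longer chain such as propyl, or holds at all on repeat measurement, remains open. Also open is how an amine or a carboxylic acid in place of the methyl of 4-methylphenyl would read, since all the aryl groups shown carry only small uncharged substituents and none has a hydrogen-bond donor or acceptor count above zero among those compared here.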